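Fluoro addition on the aromatic ring of compound 2

This account rests on a few compounds, and the source may have more. Where it says the series, first, only, none or still open, it means among the compounds named here.

Two compounds have numbers in an assay for inhibition of kynurenine 3-monooxygenase (Rattus norvegicus); a higher number here means a weaker inhibitor, a lower number a stronger inhibitor. Compound 1 `O=C(O)C(=O)/C=C(\O)c1ccc(F)c(Cl)c1` gives 270 nM. Compound 2 `N/C(=C\C(=O)c1cccc(Cl)c1)C(=O)O` gives 2400 nM, the higher of the two numbers; compound 1 is its nearest neighbour, and the gap between the two values lies beyond the scatter. Compound 1 and compound 2 differ in more than one place, so the measured pair does not isolate any single change.

Compound 3 `N/C(=C\C(=O)c1ccc(F)c(Cl)c1)C(=O)O` is not yet measured. It differs from compound 2 by fluoro in place of hydrogen on an aromatic carbon. The aromatic ring of compound 3 then matches that of compound 1, while the rest of the molecule is that of compound 2. For the measured compounds named here, no measured pair shows what this change alone does to the half-maximal inhibitory concentration. With that in mind, the step is expected to be small: the estimated change from compound 2 to compound 3 is a 1.6-fold lower number from compound 2 to compound 3 (0.20 log units; within the scatter), toward a lower number, and it may well stay within the scatter. For compound 3 the estimated value in this assay is 1500 nM, with a range from 500 nM to 4500 nM.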

Compound 3, half-maximal inhibitory concentration: 820 nM
Compound 3: the middle estimate sits 1.8-fold (0.26 log units) above what was measured; measured number inside the range.
By their numbers in this assay, from the lowest: compound 1; then compound 3; then compound 2.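

In this assay, for the compounds shown here, fluoro in place of hydrogen on the aromatic carbon ortho to the chloro group and para to the group of 8 heavy atoms gives a 2.9-fold lower number from compound 2 to compound 3 (0.47 log units; beyond the scatter) and so provides the first single change that can be read. The step is modest but lies beyond the scatter, which shows that this position is sensitive to a change of a single heavy atom. It also shows that, on the core of compound 2, fluoro at this carbon goes with a stronger inhibitor rather than a weaker one. Nothing available here accounts for the size or direction of this step.

Open, going by these compounds, is whether a nitrile or methoxy group on the same carbon would move the number in the same direction as fluoro, and whether the step would persist on a ring without the chloro group. Also open, on these data alone, is whether the fluoro step carries over to the core of compound 1, which appears here only with fluoro at this carbon.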